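Adding a methyl to the hydroxy group of compound 2

A few compounds are considered here, and "the series" means these few. Any claim that something is new, unique, unknown or untested is made for them only; others in the source may bear on it.

In a functional assay on A549/CDDP cells (Homo sapiens) for antiproliferative activity, read by MTT assay, with a stated time of 72 h (a lower number here means a stronger inhibitor, a higher number a weaker inhibitor), compound 2 `Cc1nc(C)c(/C=C/C(=O)/C=C/c2ccc(O)cc2)nc1C` gives 4790 nM and compound 1 `Cc1nc(C)c(/C=C/C(=O)/C=C/c2cccc(O)c2)nc1C` gives 3700 nM. These two sit together, with a 1.3-fold higher number from compound 1 to compound 2 (0.11 log units; within the scatter). Compound 3 `COc1cc(/C=C/C(=O)/C=C/c2nc(C)c(C)nc2C)ccc1O` gives 600 nM, a clearly separate number, with an 8.0-fold lower number from compound 2 to compound 3 (0.90 log units; beyond the scatter).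

Compound 4 `COc1ccc(/C=C/C(=O)/C=C/c2nc(C)c(C)nc2C)cc1` has not yet been measured. It differs from compound 2 by a single change, (methyl in place of hydrogen on an oxygen on an aromatic ring), which turns hydroxy to methoxy. Going by the values given here, no measured step makes this exact change, so the guidance is indirect. The step to compound 3 is the only one that adds a methoxy group, but compound 3 keeps its hydroxy group, whereas compound 4 has none. Among the compounds with values here, the shift between compound 1 and compound 2 shows only that the hydroxyphenyl change left the number within the scatter. The step expected in this assay is therefore slight and downward, estimated as a 1.6-fold lower number from compound 2 to compound 4 (0.20 log units; within the scatter), and it need not exceed the scatter. For compound 4 the estimated value is 3000 nM, with an expected range from 1000 nM to 9000 nM.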

Compound 4, half-maximal inhibitory concentration: 3610 nM
Compound 4: the middle estimate sits 1.2-fold (0.08 log units) below what was measured; the measured number falls inside the stated range.
By their numbers in this assay, from the lowest: compound 3; then compounds 4, 1 and 2 (each within the scatter of the next).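

In this assay, replacing the hydrogen on the oxygen with a methyl is a change within the scatter: a 1.3-fold lower number from compound 2 to compound 4 (0.12 log units; within the scatter). At this place on the ring, then, a hydroxy group can be exchanged for a methoxy group with no clear change in the number, and this change does not reproduce the larger step seen when a methoxy group is added on an aromatic carbon and the hydroxy group is kept, an 8.0-fold lower number from compound 2 to compound 3 (0.90 log units; beyond the scatter). The data shown offer no measured explanation for this result.

The compounds shown leave open how much larger the group on this oxygen can become, for example an ethyl or a benzyl group. They also do not show what an amine or a carboxylic acid would do in place of the hydroxy group.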